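The compounds below may be only part of what the source reports. "The series", "measured", "known", "first", "only" and "open" are said of these compounds alone.

Compound 3 `Cc1ccc(NS(=O)(=O)c2ccc(N3CCNC3=O)cc2)cc1C` stands lowest of the three numbers measured in a functional assay on M21 cells (Homo sapiens) for antiproliferative activity, read by sulforhodamine B assay, with a stated time of 48 h; on this read-out higher numbers stand for weaker inhibition and lower numbers for stronger inhibition: compound 3 gives 94 nM, whereas compound 2 `O=C1NCCN1c1ccc(S(=O)(=O)Nc2ccccc2)cc1` gives 200 nM and compound 1 `O=C1NCCN1c1ccc(S(=O)(=O)Nc2ccc(I)cc2)cc1` gives 260 nM. Both steps into compound 3 are modest but beyond the scatter, a 2.8-fold lower number from compound 1 to compound 3 (0.44 log units; beyond the scatter) and a 2.1-fold lower number from compound 2 to compound 3 (0.33 log units; beyond the scatter), while the step of a 1.3-fold lower number from compound 1 to compound 2 (0.11 log units; within the scatter) lies within the scatter. Compound 4 `Cc1ccc(C)c(NS(=O)(=O)c2ccc(N3CCNC3=O)cc2)c1` keeps the same atoms as compound 3 and joins them differently: 2,5-dimethylphenyl in place of 3,4-dimethylphenyl on a sulfonamide nitrogen. Within the data shown here, no measured step moves a methyl from one ring position to another, so the only steps that bear on this change are the two that install the dimethyl pattern at all, and both were modest. The rearranged pattern may or may not hold that gain. The expected step is a 1.9-fold higher number from compound 3 to compound 4 (0.28 log units; within the scatter), a small move, with the dimethyl gain of compound 3 partly at risk. Compound 4 is therefore estimated at 180 nM, within a range from 60 nM to 550 nM.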

Compound 4, half-maximal inhibitory concentration: 27 nM
Compound 4: the middle estimate sits 6.7-fold (0.82 log units) above what was measured; the measured number lies below the stated range.
By their numbers in this assay, from the lowest: compound 4; then compound 3; then compounds 2 and 1 (each within the scatter of the next).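

In this assay the arrangement of the two methyl groups counts by itself: with the same atoms joined differently, 2,5-dimethylphenyl in place of 3,4-dimethylphenyl on the sulfonamide nitrogen gives a 3.5-fold lower number from compound 3 to compound 4 (0.54 log units; beyond the scatter). The gap to the unsubstituted phenyl thereby widens to a 7.4-fold lower number from compound 2 to compound 4 (0.87 log units; beyond the scatter) and the gap to 4-iodophenyl to a 9.6-fold lower number from compound 1 to compound 4 (0.98 log units; beyond the scatter). Nothing among the available data bears on why this arrangement gives the lower number.

Still open, from the compounds shown here alone, is whether a single methyl group on the ring would keep the number of compound 4 or whether both are needed. Also open, going by these compounds, is whether methoxy, chloro or ethyl groups in place of the methyl groups of the 2,5-dimethylphenyl pattern would hold, lower or raise that number.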